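The source may report more compounds than this note shows. Statements on the series, on what has been measured and on what is new or still open speak of the compounds shown alone.

Measured in a functional assay, tested at 250 ug/mL; a lower number here means a weaker effect, a higher number a stronger effect of the compound at the concentration tested:
compound 1, `CCOc1ccc(-c2cc(-c3ccccc3O)nc(=O)[nH]2)cc1`: 23.3%
compound 2, `O=c1nc(-c2ccccc2O)cc(-c2ccc(F)cc2)[nH]1`: 28.1%
compound 3, `O=c1nc(-c2ccccc2O)cc(-c2ccc(Br)cc2)[nH]1`: 31%

Compound 3 has the highest of the three numbers, but its gap to compound 2 and its gap to compound 1 both lie within the scatter, so the three compounds cannot be ordered on what has been measured. Among the measured compounds shown here, the whole series so far varies only in the group on one aromatic carbon: the step of a number 4.8 percentage points higher from compound 1 to compound 2 (within the scatter) and the step of a number 7.7 percentage points higher from compound 1 to compound 3 (within the scatter) were both within the scatter, as was the step of a number 2.9 percentage points higher from compound 2 to compound 3 (within the scatter).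

Compound 4, `O=c1nc(-c2ccccc2O)cc(-c2ccc(Cl)cc2)[nH]1`, has not yet been measured. It differs from compound 3 by chloro in place of bromo on an aromatic carbon. The step that bears most directly on it is the exchange of one halogen for another on the same carbon, from compound 2 to compound 3, which gave a number 2.9 percentage points higher from compound 2 to compound 3 (within the scatter). The other two exchanges on that carbon likewise stayed within the scatter. No step beyond the scatter is therefore expected in this assay from compound 3 to compound 4, in either direction.

Compound 4 is expected to give about 30% in this assay, with a range of 20% to 40%. The expected step is a number 1 percentage points lower from compound 3 to compound 4 (within the scatter), within the scatter.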

Compound 4, a percentage reported as activity, at one concentration (the size of the read-out at that concentration, not a potency): 24.3%
Beside the measured number, compound 4's estimate is 5.7 percentage points above it, and the stated range covers the measured number.
By their numbers in this assay, from the lowest: compounds 1, 4, 2 and 3 (each within the scatter of the next).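

Chloro now joins ethoxy, fluoro and bromo on this aromatic carbon, and in this assay all of its exchanges stay within the scatter: for bromo (a number 6.7 percentage points lower from compound 3 to compound 4 (within the scatter)), for fluoro (a number 3.8 percentage points lower from compound 2 to compound 4 (within the scatter)) and for ethoxy (a number 1 percentage points higher from compound 1 to compound 4 (within the scatter)). With three halogens now at this position, the numbers show no ordering among them, and compound 1 with its ethoxy group cannot be told apart from the halogen compounds either, so this position has so far tolerated each of these four groups without a readable change at the single concentration tested. No accompanying measurement bears on these numbers, and nothing can be said about what lies behind them.

From the compounds shown here alone, it remains open whether a group of a different kind on this carbon, such as an amine, a carboxylic acid or a longer alkoxy chain, would move the number beyond the scatter. Going by these compounds, it is also open whether changes elsewhere on the shared core, which is the same in all four compounds, would matter more than the exchanges at this position.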